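This account rests on a few compounds, and the source may have more. Where it says the series, first, only, none or still open, it means among the compounds named here.

Measured so far:
- compound 1, `COc1ccc([C@H](O)[C@H]2CO[C@@H](c3ccc(OC)c(OC)c3)[C@H](C/C=C/c3ccc(OC)c(OC)c3)C2)cc1`: 32200 nM
- compound 2, `COc1cccc(/C=C/C[C@H]2C[C@@H]([C@@H](O)c3ccccc3)CO[C@@H]2c2ccccc2)c1`: 10900 nM
- compound 3, `COc1ccc([C@@H]2OC[C@H]([C@@H](O)c3ccc(OC)c(OC)c3)C[C@H]2C/C=C/c2ccc(OC)c(OC)c2)cc1`: 29200 nM

All three were tested in a functional assay on HeLa cells (Homo sapiens) for cytotoxicity, read by WST assay, with a stated time of 48 h; on this read-out higher numbers stand for weaker inhibition and lower numbers for stronger inhibition. Compound 2 gives the lowest number of the three: compound 3 stands a clear way above it, and compound 1 further still, both gaps beyond the usual scatter, so compound 2 counts as the most potent of the measured set. Going by the values given here, no two of the measured compounds differ from each other in only one place, so no single structural step between measured values can be read off.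

Compound 4, `O=[N+]([O-])c1cccc(/C=C/C[C@H]2C[C@@H]([C@@H](O)c3ccccc3)CO[C@@H]2c2ccccc2)c1`, has not yet been measured in this assay. It differs from compound 2 in one place: nitro in place of methoxy on an aromatic carbon

Among the compounds with values here, no measured pair shows what this exchange does, so the expectation rests on compound 2 alone. Absent such evidence, the step is expected to be small, in either direction, and not beyond the scatter. Compound 4 is therefore expected to give about 10000 nM, with a plausible range from 4000 nM to 25000 nM. The step this estimate implies, a 1.1-fold lower number from compound 2 to compound 4 (0.04 log units; within the scatter), is expected to lie within the scatter.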

Compound 4, half-maximal inhibitory concentration: 7850 nM
For compound 4 the middle estimate is 1.3-fold (0.11 log units) above the measured one, and the stated range covers the measured number.
By their numbers in this assay, from the lowest: compounds 4 and 2 (each within the scatter of the next); then compounds 3 and 1 (each within the scatter of the next).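

In this assay, going by these compounds alone, the change from 3-methoxyphenyl to 3-nitrophenyl gives a 1.4-fold lower number from compound 2 to compound 4 (0.14 log units; within the scatter) and is the first step in this set that can be read at a single place in the structure. It shows that, at this position on the aromatic ring, meta to a large group, methoxy can give way to nitro, a group with more heavy atoms and more hydrogen-bond acceptors, without a difference that stands out from the scatter of repeated measurements. The two groups therefore cannot be told apart by this read-out at this position, although that finding rests on this single pair. No measurement is available that explains why the two numbers lie so close together.

From the compounds shown here alone, it remains open whether this position is as forgiving of groups of a different kind, such as an amine or a carboxylic acid, or whether a plain hydrogen there would give a similar number. The same exchange is also untested by these data on the more heavily substituted compounds, such as compound 1 and compound 3, so nothing can yet be carried over to them.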